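The source may hold more compounds than are shown below. What is called first, only, known or untested is meant among the compounds shown, and "the series" means these compounds.

Measured so far:
Compound 1 `CN(C)CCn1cnnc1-c1cc(Oc2ccc(NC(=O)N/N=C/c3ccccc3)cc2F)ccn1`: 2730 nM
Compound 2 `CN(C)CCn1cnnc1-c1cc(Oc2ccc(NC(=O)N/N=C/c3ccc(F)cc3)cc2F)ccn1`: 1030 nM
Compound 3 `CN(C)CCn1cnnc1-c1cc(Oc2ccc(NC(=O)N/N=C/c3ccc(O)cc3)cc2F)ccn1`: 820 nM

All three compounds share a core and were tested in a functional assay on MKN-45 cells (Homo sapiens) for cytotoxicity, read by MTT assay, with a stated time of 72 h; a lower number here means a stronger inhibitor, a higher number a weaker inhibitor. From compound 1 the change fluoro in place of hydrogen on an aromatic carbon gave a step of a 2.7-fold lower number from compound 1 to compound 2 (0.42 log units; beyond the scatter), and the change hydroxy in place of hydrogen on an aromatic carbon gave a step of a 3.3-fold lower number from compound 1 to compound 3 (0.52 log units; beyond the scatter). Compound 2 and compound 3 lie within the scatter of each other, a 1.3-fold lower number from compound 2 to compound 3 (0.10 log units; within the scatter), so no order between them is claimed.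

Compound 4 `CN(C)CCn1cnnc1-c1cc(Oc2ccc(NC(=O)N/N=C/c3ccc(O)c(F)c3)cc2F)ccn1` has not yet been measured in this assay. It differs from compound 3 by fluoro in place of hydrogen on an aromatic carbon. Within the data shown here, this is the same kind of change as the one from compound 1 to compound 2, which was fluoro in place of hydrogen on an aromatic carbon and made the step of a 2.7-fold lower number from compound 1 to compound 2 (0.42 log units; beyond the scatter). The surroundings of the place are not identical: in compound 2 the fluoro sits para to a large group, whereas in compound 4 it sits ortho to a hydroxy group and meta to a large group. The two cores themselves differ by hydroxy in place of hydrogen on an aromatic carbon.

On the strength of the earlier step, and allowing that the altered surroundings may blunt it, compound 4 is expected to show a step of a 1.6-fold lower number from compound 3 to compound 4 (0.21 log units; within the scatter) relative to compound 3. The estimate for compound 4 in this assay is 500 nM, with a likely range from 200 nM to 1300 nM.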

Compound 4, half-maximal inhibitory concentration: 1970 nM
For compound 4 the middle estimate is 3.9-fold (0.60 log units) below the measured one; measured number above the stated range.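

In this assay, fluoro in place of hydrogen on an aromatic carbon did not carry over from one core to the other, for on the core bearing the hydroxy group the step is a 2.4-fold higher number from compound 3 to compound 4 (0.38 log units; beyond the scatter), and the two steps run in opposite directions and differ: the same change on two cores in this assay, a 2.7-fold lower number (0.42 log units; beyond the scatter) from compound 1 to compound 2 and a 2.4-fold higher number (0.38 log units; beyond the scatter) from compound 3 to compound 4, 6.4-fold (0.80 log units) apart, beyond the scatter of two such steps. The other two new steps, a 1.9-fold higher number from compound 2 to compound 4 (0.28 log units; within the scatter) and a 1.4-fold lower number from compound 1 to compound 4 (0.14 log units; within the scatter), are within the scatter, so the 3-fluoro-4-hydroxyphenyl group cannot be ranked against either the 4-fluorophenyl or the phenyl group. Among these compounds, this shows that, in this series, the size and direction of the fluoro step cannot be taken from one core to another, but with only two such pairs, in which the place of the fluoro also differs, it does not show whether the hydroxy group or that place decides the outcome.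

The compounds shown leave open how a 3-fluorophenyl group would behave, which would separate the place of the fluoro from the presence of the hydroxy group. They also leave open whether a methoxy group in place of the hydroxy, or chloro in place of the fluoro, would give the same reversal.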